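Changing the Side Chain of Compound 3

This account rests on a few compounds, and the source may have more. Where it says the series, first, only, none or still open, it means among the compounds named here.

For the measured compounds named here, in a functional assay on L02 cells (Homo sapiens) for cytotoxicity, read by MTT assay, with stated times of 48 h and 4 h (a lower number here means a stronger inhibitor, a higher number a weaker inhibitor), compound 3 `CC(C)N(CCNc1nc(/C=C/c2ccc([N+](=O)[O-])cc2)nc2ccccc12)C(C)C` gives 8960 nM, the lowest number measured so far. Compound 2 `COc1ccc(/C=C/c2nc(NCCN(C)C)c3cc(Cl)ccc3n2)cc1OC` gives a higher 80500 nM. Compound 1 `COc1ccc(/C=C/c2nc(NCCN(C(C)C)C(C)C)c3ccccc3n2)cc1OC` gives > 100000 nM, which is a limit of the assay and not a number.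

Compound 4 `NCCCCNc1nc(/C=C/c2ccc([N+](=O)[O-])cc2)nc2ccccc12` keeps the 4-nitrophenyl group of compound 3 but changes the side chain. It carries 2-aminoethyl in place of diisopropylamino on a saturated chain carbon, two bonds along the chain from a nitrogen on an aromatic ring. Read one cut further out, (2-(diisopropylamino)ethyl)amino becomes (4-aminobutyl)amino.

Going by the values given here, the only measured step is an at least 11-fold lower number from compound 1 to compound 3 (1.04 log units; beyond the scatter). It is large, but it exchanges 3,4-dimethoxyphenyl for 4-nitrophenyl and leaves the diisopropylamino group untouched. Among the compounds with values here, it therefore bears only indirectly on this change, and no measured step isolates the side chain. With no measured direction to follow, no step beyond the scatter is expected in this assay, although the uncertainty is wide. The expected change is a 1.3-fold lower number from compound 3 to compound 4 (0.11 log units; within the scatter). The estimate for compound 4 is 7000 nM, with an expected range of 1800 nM to 30000 nM.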

Compound 4, half-maximal inhibitory concentration: 7460 nM
Compound 4: middle estimate off by 1.1-fold (0.03 log units), on the low side; the measured number falls inside the stated range.
By their numbers in this assay, from the lowest: compounds 4 and 3 (each within the scatter of the next); then compound 2. At a limit, above all of these: compound 1.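

For the compounds shown here, compound 4 gives the first measured reading of a change to the side chain, since the only earlier step exchanged the 3,4-dimethoxyphenyl group for 4-nitrophenyl. On a saturated chain carbon, two bonds along the chain from a nitrogen on an aromatic ring, diisopropylamino with 7 heavy atoms gives way to 2-aminoethyl with 3 heavy atoms and 1 hydrogen-bond donor, and this assay shows a 1.2-fold lower number from compound 3 to compound 4 (0.08 log units; within the scatter), so this large exchange of groups leaves the two compounds indistinguishable here. Nothing in the available evidence accounts for this outcome.

The exchange also turns 2-(diisopropylamino)ethyl into 4-aminobutyl, so this single pair cannot separate the effect of the longer chain from that of the different amine, which would take a compound such as one with a 2-aminoethyl chain carrying dimethylamino or a 4-aminobutyl chain carrying diisopropylamino. It also leaves open whether a carboxylic acid or a piperidine in this place would behave the same way, and whether the result holds with 3,4-dimethoxyphenyl in place of 4-nitrophenyl.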